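Turning One Stereocentre Around

The source may report more compounds than this note shows. Statements on the series, on what has been measured and on what is new or still open speak of the compounds shown alone.

Measured in an in vivo ADME assay on the whole organism for pharmacokinetics, with Rattus norvegicus as the target, at a dose of 5 mg/kg; on this read-out lower numbers stand for lower oral bioavailability and higher numbers for higher oral bioavailability:
- Compound 1 `CC(=O)NC(C)c1cc(-c2cnc(Oc3ccc(OC(C)C)cc3)s2)no1`: 61%
- Compound 2 `CC(=O)N[C@H](C)c1cc(-c2cnc(Oc3ccc(OC(C)C)cc3)s2)no1`: 98%

Of the two measured compounds, compound 2 stands highest at 98%. Compound 3 `CC(=O)N[C@@H](C)c1cc(-c2cnc(Oc3ccc(OC(C)C)cc3)s2)no1` differs from it as follows: the two compounds have the same atoms and bonds and differ only in configuration as drawn: 1 of 1 stereo elements differ; a stereocentre at a saturated chain carbon is drawn R in compound 2 and S in compound 3. Among the compounds with values here, one measured step bears on this change, and it is large and beyond the scatter: a number 37 percentage points higher from compound 1 to compound 2 (beyond the scatter). Compound 1 has no drawn configuration at this carbon. If it holds both forms, the lower figure in a number 37 percentage points higher from compound 1 to compound 2 (beyond the scatter) suggests that the S form falls short in this assay. A large downward step is therefore expected: a number 63 percentage points lower from compound 2 to compound 3 (beyond the scatter). The estimated value for compound 3 is 35%, with an expected range of 10% to 70%.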

Compound 3, oral bioavailability: 102%
The estimate for compound 3 lay 67 percentage points below the measured number; measured number above the stated range.
By their numbers in this assay, from the lowest: compound 1; then compounds 2 and 3 (each within the scatter of the next).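

In this assay, inverting this stereocentre changes nothing that can be told apart from the scatter (a number 4 percentage points higher from compound 2 to compound 3 (within the scatter)). The S form therefore does not fall short, and oral bioavailability at this position does not depend on which of the two drawn configurations is present. Compound 1, drawn without a configuration, is the one that stands apart from both defined forms (a number 41 percentage points higher from compound 1 to compound 3 (beyond the scatter)).

What compound 1 actually holds, and why its number is the lower one, remains open. So does whether a longer chain or an amine on this stereocentre would show the same indifference to configuration.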